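Cytotoxicity notes: removing the ring fluorine from compound 1

A few compounds are considered here, and "the series" means these few. Any claim that something is new, unique, unknown or untested is made for them only; others in the source may bear on it.

Measured compounds in an ADME assay on MT4 cells (Homo sapiens) for cytotoxicity, read by MTT assay, with a stated time of 5 days; a lower number here means that less compound is tolerated, a higher number that more compound is tolerated:
- compound 1, `N#Cc1ccc(Nc2nccc(OCc3ccc(F)cc3)n2)cc1`, 81000 nM
- compound 2, `Cc1ccccc1COc1ccnc(Nc2ccc(C#N)cc2)n1`, 12000 nM
- compound 3, `Cc1ccc(COc2ccnc(Nc3ccc(C#N)cc3)n2)cc1`, 81000 nM

Compound 1 stands level with compound 3 at the digits printed, and together they give the highest of the three numbers; compound 2 is the only one set apart, with a 6.8-fold lower number from compound 1 to compound 2 (0.83 log units; beyond the scatter). The same distance appears between compound 2 and compound 3, a 6.8-fold higher number from compound 2 to compound 3 (0.83 log units; beyond the scatter), so the two benzyl groups with a substituent on the carbon bound to the ring oxygen in the 4-position behave alike, while the 2-methylphenyl stands apart.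

Compound 4, `N#Cc1ccc(Nc2nccc(OCc3ccccc3)n2)cc1`, differs from compound 1 as follows: hydrogen in place of fluoro on an aromatic carbon. The step that bears most directly on it is no change at the digits printed from compound 1 to compound 3 (within the scatter), where one small group on the same aromatic carbon was exchanged for another without moving the number. Nothing in the measured set shows that the occupant of that carbon matters in this assay. The expectation for compound 4 is therefore a step of no change at the digits printed from compound 1 to compound 4 (within the scatter), that is no change beyond the scatter.

Compound 4 is estimated at 81000 nM, with a range from 35000 nM to 160000 nM.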

Compound 4, half-maximal cytotoxic concentration: 13000 nM
Compound 4: middle estimate off by 6.2-fold (0.79 log units), on the high side, outside the stated range (below it).
By their numbers in this assay, from the lowest: compounds 2 and 4 (each within the scatter of the next); then compounds 1 and 3 (each within the scatter of the next).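

In this assay the aromatic carbon para to a large group turns out to respond to its occupant: fluoro and methyl there could not be told apart, but hydrogen is set apart from both (a 6.2-fold lower number from compound 1 to compound 4 (0.79 log units; beyond the scatter); a 6.2-fold lower number from compound 3 to compound 4 (0.79 log units; beyond the scatter)). Compound 2 now has company at the lower level (a 1.1-fold higher number from compound 2 to compound 4 (0.03 log units; within the scatter)), so the 2-methylphenyl group no longer stands alone, and among these four compounds the two with a group on that carbon, compound 1 and compound 3, are the pair set apart, while the methyl of compound 2, in its 2-position, goes with no such rise. Nothing at hand explains why a fluoro or a methyl on that carbon goes with the higher number.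

On these data alone, two occupants are too few to show how far this holds, so it remains open whether a chloro, a methoxy, an amine or a carboxylic acid on that carbon would sit with fluoro and methyl or with hydrogen. Also open, as far as these compounds go, is whether the same step would appear with a longer chain in place of the benzyl link to the shared core.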